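This account rests on a few compounds, and the source may have more. Where it says the series, first, only, none or still open, it means among the compounds named here.

Compound 2 `O=C(NN=C1CC(c2ccccc2)NC(c2ccccc2)C1)c1ccc(Cl)cc1`: in a functional assay on A549 cells (Homo sapiens) for cytotoxicity, read by MTT assay, with a stated time of 24 h (on this read-out lower numbers stand for stronger inhibition and higher numbers for weaker inhibition), compound 2 gives > 400000 nM, a limit of the assay rather than a number.
Compound 3 `O=C(NN=C1CC(c2ccccc2)NC(c2ccccc2)C1)c1ccc([N+](=O)[O-])cc1[N+](=O)[O-]`: in this assay compound 3 gives > 400000 nM, again a limit.
Compound 1 `CCOC(=O)N1CCC(=NNC(=O)c2ccc([N+](=O)[O-])cc2[N+](=O)[O-])CC1`: in this assay compound 1 gives 27300000 nM.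

Compound 2 therefore stands at the edge of what this assay can report, and it is not alone there: the limit of > 400000 nM in this assay, at which 2 of the 3 values shown sit. Compound 4 `O=C(NN=C1CC(c2ccccc2)NC(c2ccccc2)C1)c1ccc(F)cc1C(F)(F)F` differs from compound 2 in one place, (4-fluoro-2-(trifluoromethyl)phenyl in place of 4-chlorophenyl on a carbonyl carbon), that is 4-fluoro-2-(trifluoromethyl)phenyl in place of 4-chlorophenyl on a carbonyl carbon. Among the measured compounds shown here, no measured pair shows what such a change does here, so no shift beyond the usual scatter is expected. Compound 4 is estimated at 800000 nM, in the range 300000 nM to 5000000 nM, and the expected step that the limit leaves unreadable from compound 2 to compound 4 is essentially none.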

Compound 4, half-maximal inhibitory concentration: > 400000 nM
Compound 4 was reported as a limit; the forecaster's own chance of this, stated with the estimate: 70%; the middle value lies beyond the limit too.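

Compound 2 and compound 4 both stop at a limit rather than a number, so no step between them can be read: the limit of > 400000 nM in this assay, at which 3 of the 4 values shown sit.

From the compounds shown here alone, what swapping the group on the carbonyl carbon does in this assay stays open.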